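The compounds below may be only part of what the source reports. "The series", "measured", "known", "first", "only" and "open" are said of these compounds alone.

Measured in a functional assay on K562 cells (Homo sapiens) for cytotoxicity, read by trypan blue exclusion, with a stated time of 96 h; a higher number here means a weaker inhibitor, a lower number a stronger inhibitor
compound 1 `COc1cc(OC)c(/C=C/S(=O)(=O)Nc2ccc(OC)c(F)c2)c(OC)c1` gives 75 nM
compound 2 `COc1cc(OC)c(/C=C/S(=O)(=O)Nc2ccc(OC)c(O)c2)c(OC)c1` gives 15 nM
compound 3 `COc1cc(OC)c(/C=C/S(=O)(=O)Nc2ccc(OC)c(N)c2)c(OC)c1` gives 3 nM

Compound 3 stands lowest of the three, with a 5.0-fold lower number from compound 2 to compound 3 (0.70 log units; beyond the scatter) and a 25-fold lower number from compound 1 to compound 3 (1.40 log units; beyond the scatter) leading to it. The remaining measured step is a 5.0-fold lower number from compound 1 to compound 2 (0.70 log units; beyond the scatter). Compound 4 `COC(=O)C(C)Nc1cc(NS(=O)(=O)/C=C/c2c(OC)cc(OC)cc2OC)ccc1OC` has 1-(methoxycarbonyl)ethyl in place of hydrogen on a nitrogen on an aromatic ring. The measured steps exchange fluoro, hydroxy and amino, and none substitutes on the amino nitrogen, so they bear only indirectly. Compound 4 loses the unsubstituted amino of compound 3, and the move from hydroxy to amino gave a 5.0-fold lower number from compound 2 to compound 3 (0.70 log units; beyond the scatter). A modest step to a higher number is therefore expected in this assay. The expected step is a 5.0-fold higher number from compound 3 to compound 4 (0.70 log units; beyond the scatter). For compound 4 the estimated value is 15 nM (range 4 nM to 80 nM).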

Compound 4, half-maximal inhibitory concentration: 300 nM
Compound 4: the middle estimate sits 20-fold (1.30 log units) below what was measured; measured number above the stated range.
By their numbers in this assay, from the lowest: compound 3; then compound 2; then compound 1; then compound 4.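

In this assay, 1-(methoxycarbonyl)ethyl on the amino nitrogen gives the largest change seen at this position, a 100-fold higher number from compound 3 to compound 4 (2.00 log units; beyond the scatter), so the gain from amino does not survive this substitution. The substituted compound also falls behind the hydroxy and fluoro compounds, with a 20-fold higher number from compound 2 to compound 4 (1.30 log units; beyond the scatter) and a 4.0-fold higher number from compound 1 to compound 4 (0.60 log units; beyond the scatter) on the same scale. Nothing at hand accounts for this loss.

The compounds shown leave open whether the loss follows from any substituent on this nitrogen or from this one. A plain methyl there, or the carboxylic acid in place of the methyl ester, would separate these.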